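The source may report more compounds than this note shows. Statements on the series, on what has been measured and on what is new or still open speak of the compounds shown alone.

Of the compounds shown here, three have numbers so far in a functional assay on PC-3 cells (Homo sapiens) for inhibition, read by sulforhodamine B assay; on this read-out lower numbers stand for stronger inhibition of growth and higher numbers for weaker inhibition of growth. Compound 1 `Oc1ccc(-c2ccc(-c3ccc(-c4nc5ccccc5[nH]4)cc3)cc2)cc1` gives 47000 nM, compound 2 `Oc1cccc2[nH]c(-c3ccc(-c4ccc(-c5ccccc5)cc4)cc3)nc12` gives 1240 nM, and compound 3 `Oc1cccc2[nH]c(-c3ccc(-c4ccc(-c5ccc(C(F)(F)F)cc5)cc4)cc3)nc12` gives 2260 nM. Compound 3 therefore stands within the scatter of compound 2 and far below compound 1.

The next molecule, compound 4 `Oc1ccc(-c2ccc(-c3ccc(-c4nc5c(O)cccc5[nH]4)cc3)cc2)cc1`, changes one group of compound 3: hydroxy in place of trifluoromethyl on an aromatic carbon. In words, this is hydroxy in place of trifluoromethyl on an aromatic carbon, para to a large group.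

Going by the values given here, the only measured step at this place is a 1.8-fold higher number from compound 2 to compound 3 (0.26 log units; within the scatter), and it lies within the scatter. Swapping hydrogen for trifluoromethyl there did not move the number measurably, which suggests that this place may tolerate change. Among the compounds with values here, no measured pair shows hydroxy entering there directly. Compound 4 carries the same 4-hydroxyphenyl as compound 1, and compound 1 gives a much higher 47000 nM. However, it lacks the other hydroxy shared by compound 2, compound 3 and compound 4, so it cannot isolate the effect of this swap. It is still reason to leave the range wide on the upper side.

The step expected is modest and upward, a 1.3-fold higher number from compound 3 to compound 4 (0.12 log units; within the scatter), and not clearly beyond the scatter. For compound 4 the estimated value is 3000 nM, with an expected range from 800 nM to 15000 nM.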

Compound 4, concentration for 50% growth inhibition: 190 nM
Estimate against measurement, compound 4: 16-fold (1.20 log units) above; the measured number lies below the stated range.
By their numbers in this assay, from the lowest: compound 4; then compounds 2 and 3 (each within the scatter of the next); then compound 1.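

In this assay this place, on an aromatic carbon para to a large group, proves far from indifferent: hydroxy in place of trifluoromethyl gives a 12-fold lower number from compound 3 to compound 4 (1.08 log units; beyond the scatter) and hydroxy in place of hydrogen gives a 6.5-fold lower number from compound 2 to compound 4 (0.81 log units; beyond the scatter). The earlier swap of hydrogen for trifluoromethyl gave a 1.8-fold higher number from compound 2 to compound 3 (0.26 log units; within the scatter) and so did not show this, which means that among the three groups seen here only hydroxy moves the number beyond the scatter. The 4-hydroxyphenyl group does not produce the low number on its own, since adding hydroxy on the core, the other place where these compounds differ, gives a 250-fold lower number from compound 1 to compound 4 (2.39 log units; beyond the scatter) and shows that the core hydroxy matters as well.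

No supporting measurement accounts for the gain seen with hydroxy. Going by these compounds, it remains open whether an amine or a methoxy group at this same place would give a number like that of compound 4, and whether the two hydroxy groups would still work together on a different core.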